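The compounds below may be only part of what the source reports. "The series", "measured", "known", "first", "only" and "open" are said of these compounds alone.

Measured so far:
- compound 1, `CC1=C(SCCCO)C(=O)c2ccccc2C1=O`: 5160 nM
- compound 2, `CC1=C(SCCCCO)C(=O)c2ccccc2C1=O`: 5780 nM
- compound 3, `CC1=C(SCCCCCCO)C(=O)c2ccccc2C1=O`: 9280 nM

In a functional assay on MCF7 cells (Homo sapiens) for inhibition (a higher number here means a weaker inhibitor, a lower number a stronger inhibitor), compound 3 gives 9280 nM, the highest number of the three; its nearest neighbour is compound 2 with 5780 nM, and compound 1 with 5160 nM sits furthest off, but both gaps are within the scatter, so no order among the three can be read.

Compound 4, `CC1=C(SC(C)C(C)O)C(=O)c2ccccc2C1=O`, is not yet measured. The change from compound 3 is 2-hydroxy-1-methylpropyl in place of 6-hydroxyhexyl on a sulfur. For the measured compounds named here, no measured step changes the chain in this way. The steps on hand only lengthen the hydroxyalkyl chain on the sulfur: a 1.1-fold higher number from compound 1 to compound 2 (0.05 log units; within the scatter), a 1.8-fold higher number from compound 1 to compound 3 (0.25 log units; within the scatter) and a 1.6-fold higher number from compound 2 to compound 3 (0.21 log units; within the scatter), all within the scatter. Chain length therefore leaves this assay largely untouched across the measured set; a shorter, branched chain is outside that set, but nothing measured points to a step beyond the scatter.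

Compound 4 is expected to land near the measured compounds, with an estimated step of a 1.5-fold lower number from compound 3 to compound 4 (0.19 log units; within the scatter) and an estimate of 6000 nM, range 2000 nM to 18000 nM.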

Compound 4, half-maximal inhibitory concentration: > 10000 nM
Compound 4 gave a limit, no number (the forecaster's own chance of this, stated with the estimate: 10%); middle value at least 1.6-fold (0.22 log units) away from the limit.
By their numbers in this assay, from the lowest: compounds 1, 2 and 3 (each within the scatter of the next). At a limit, above all of these: compound 4.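

In this assay compound 4, with 2-hydroxy-1-methylpropyl on the sulfur, reads only as a limit and not as a number: the limit of > 10000 nM in this assay, at which 1 of the 4 values shown sits.

The steps to it are therefore floors: an at least 1.0-fold higher number from compound 3 to compound 4 (0.03 log units; that floor lies within the scatter), an at least 1.7-fold higher number from compound 2 to compound 4 (0.23 log units; that floor lies within the scatter) and an at least 1.9-fold higher number from compound 1 to compound 4 (0.28 log units; that floor lies within the scatter). So this branched chain is not shown to differ beyond the scatter from any of the straight hydroxyalkyl chains, yet it is the first group at this position on the sulfur to give no number, and the true size of the change stays undetermined.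

Open, on these data alone, is whether the methyl branch or the place of the hydroxy on the chain goes with this limit. Also open, as far as these compounds go, is how an amine or a carboxylic acid in place of the hydroxy would read in this assay.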